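Oxytocin Receptor Binding: Bromofuran Replaced by Pyridylthiophene

The source may report more compounds than this note shows. Statements on the series, on what has been measured and on what is new or still open speak of the compounds shown alone.

The measured compounds and their values in an assay on isolated protein for binding affinity to Oxytocin receptor (Homo sapiens); on this read-out lower numbers stand for stronger inhibition and higher numbers for weaker inhibition:
Compound 1, `Cc1cc([C@H](C(=O)NC(C)C)N2C(=O)[C@@H](C3Cc4ccccc4C3)NC(=O)[C@H]2CC(C)C)oc1C`, gives 1.26 nM.
Compound 2, `CNC(=O)c1ccc([C@H](C(=O)NC(C)C)N2C(=O)[C@@H](C3Cc4ccccc4C3)NC(=O)[C@H]2CC(C)C)o1`, gives 39.8 nM.
Compound 3, `CC(C)C[C@@H]1C(=O)N[C@H](C2Cc3ccccc3C2)C(=O)N1[C@@H](C(=O)NC(C)C)c1ccc(Br)o1`, gives 0.794 nM.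

Compound 3 has the lowest number of the three. Its nearest neighbour is compound 1, with a 1.6-fold lower number from compound 1 to compound 3 (0.20 log units; within the scatter), a step that stays within the scatter, so the two cannot be ranked against each other. The furthest is compound 2, with a 50-fold lower number from compound 2 to compound 3 (1.70 log units; beyond the scatter), a large step well beyond the scatter.

Compound 4, `CC(C)C[C@@H]1C(=O)N[C@H](C2Cc3ccccc3C2)C(=O)N1[C@@H](C(=O)NC(C)C)c1ccc(-c2ccccn2)s1`, differs from compound 3 in one place: 5-(pyridin-2-yl)thiophen-2-yl in place of 5-bromofuran-2-yl on a saturated chain carbon bound to an amide-type nitrogen in a ring and a carbonyl carbon. Among the compounds with values here, two measured steps bear on this position. The swap of small substituents on the furan, a 1.6-fold lower number from compound 1 to compound 3 (0.20 log units; within the scatter), changed little. Introducing a group with an added acceptor, a 32-fold higher number from compound 1 to compound 2 (1.50 log units; beyond the scatter), cost a great deal, and removing it, a 50-fold lower number from compound 2 to compound 3 (1.70 log units; beyond the scatter), recovered it. The entering group of compound 4 brings a second acceptor and a second ring, a larger change than any measured here, so a moderate rise in this assay is expected, a 6.3-fold higher number from compound 3 to compound 4 (0.80 log units; beyond the scatter). Compound 4 is thus estimated at 5 nM, with a range of 1 nM to 30 nM.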

Compound 4, inhibition constant: 2.51 nM
Compound 4: middle estimate off by 2.0-fold (0.30 log units), on the high side; low and high end bracket the measured number.
By their numbers in this assay, from the lowest: compounds 3, 1 and 4 (each within the scatter of the next, the first and the last beyond it); then compound 2.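

In this assay this position accepts a much larger two-ring group at a modest price, a 3.2-fold higher number from compound 3 to compound 4 (0.50 log units; beyond the scatter), while the step from the dimethylfuran, a 2.0-fold higher number from compound 1 to compound 4 (0.30 log units; within the scatter), stays within the scatter, so those two cannot be ranked. Heavy-atom count alone does not set the number among these compounds: 5-(pyridin-2-yl)thiophen-2-yl, with 11 heavy atoms, replaces the methylcarbamoyl-bearing group of 9 heavy atoms and gives a 16-fold lower number from compound 2 to compound 4 (1.20 log units; beyond the scatter), so the larger group here does not carry the cost seen with the methylcarbamoyl group. Nothing available here accounts for the difference between these two groups.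

The compounds shown leave open how much of the modest step belongs to the thiophene and how much to the pyridine, since both enter together in compound 4. On these data alone, how a phenyl ring in place of the pyridin-2-yl, or a carboxylic acid or an amine in place of the methylcarbamoyl, would read at this position also stays open.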